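A few compounds are considered here, and "the series" means these few. Any claim that something is new, unique, unknown or untested is made for them only; others in the source may bear on it.

Measured so far in a functional assay on A549 cells (Homo sapiens), read by MTT assay, with a stated time of 72 h (on this read-out higher numbers stand for weaker inhibition and lower numbers for stronger inhibition), are two compounds:
- compound 1 `COc1ncnc2c1c(-c1ccccc1)cn2[C@@H]1O[C@H](CO)[C@@H](O)[C@H]1O` gives > 20000 nM (a limit)
- compound 2 `Nc1nc2c(c(-c3ccco3)cn2[C@@H]2O[C@H](CO)[C@@H](O)[C@H]2O)c(=O)[nH]1` gives > 20000 nM (a limit)

Neither entry is a true number, since each is only a limit of the assay. Compound 2 stands at the limit of > 20000 nM in this assay, at which 2 of the 2 values shown sit, and so offers no exact starting value. Compound 3 `Nc1nc2c(c(-c3cc4ccccc4o3)cn2[C@@H]2O[C@H](CO)[C@@H](O)[C@H]2O)c(=O)[nH]1` carries 1-benzofuran-2-yl in place of furan-2-yl on an aromatic carbon of the shared core (1-benzofuran-2-yl in place of furan-2-yl on an aromatic carbon). Among the measured compounds shown here, no measured pair here shows what such a swap does. In this assay no change beyond the usual scatter is expected, and this rests on compound 2 with its limit of > 20000 nM as the only close relative. The expected size of the change is a number no higher from compound 2 to compound 3 (the limit leaves the size open) in either direction. For compound 3 the estimate is 20000 nM with an expected range from 8000 nM to 40000 nM and the result will quite likely be reported only as a limit.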

Compound 3, half-maximal inhibitory concentration: > 100000 nM
Compound 3: no number, only a limit; the forecaster's own chance of this, stated with the estimate: 85%; middle value at least 5.0-fold (0.69 log units) away from the limit.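

Among the compounds shown here, compound 2 and compound 3 are both reported only as limits in this assay, so no step between them can be read. The compounds shown leave open whether 1-benzofuran-2-yl in place of furan-2-yl changes inhibition at all, and what true value either compound has.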